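From 4-chlorophenyl to 4-bromophenyl: working notes

This account rests on a few compounds, and the source may have more. Where it says the series, first, only, none or still open, it means among the compounds named here.

Series in a functional assay on HL-60 cells (Homo sapiens) for cytotoxicity, read by MTT assay, with a stated time of 46 h; on this read-out lower numbers stand for stronger inhibition and higher numbers for weaker inhibition:
- compound 1 `O=C1/C(=C\c2ccccc2)C(c2ccccc2)Oc2ccccc21`: 27300 nM
- compound 2 `Cc1ccc(/C=C2\C(=O)c3ccccc3OC2c2ccccc2)cc1`: 40800 nM
- compound 3 `O=C1/C(=C\c2ccc(Cl)cc2)C(c2ccccc2)Oc2ccccc21`: > 1000000 nM, a limit
- compound 4 `O=C1/C(=C\c2ccc(Br)cc2)C(c2ccccc2)Oc2ccccc21`: not yet measured

Compound 3 is the weakest of the three measured compounds in this assay. For compound 3, the reading of > 1000000 nM is a limit and not a number.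

Compound 4 carries bromo in place of chloro on an aromatic carbon. Among the measured compounds shown here, no measured step makes this exchange, so the evidence is indirect. Chloro in place of hydrogen gave an at least 36-fold higher number from compound 1 to compound 3 (1.56 log units; beyond the scatter), and chloro in place of methyl gave an at least 24-fold higher number from compound 2 to compound 3 (1.38 log units; beyond the scatter). Both steps are large, whereas methyl in place of hydrogen gave a 1.5-fold higher number from compound 1 to compound 2 (0.17 log units; within the scatter), within the scatter.

On the strength of an at least 36-fold higher number from compound 1 to compound 3 (1.56 log units; beyond the scatter), bromo is expected to stay near the weak end rather than return to the level of the unsubstituted compound 1. The expected step is an at least 3.3-fold lower number from compound 3 to compound 4 (0.52 log units; beyond the scatter), and a second limit reading would be no surprise. For compound 4 the estimated value is 300000 nM, with an expected range of 40000 nM to 1000000 nM.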

Compound 4, half-maximal inhibitory concentration: > 1000000 nM
Compound 4 was reported as a limit (the forecaster's own chance of this, stated with the estimate: 50%); at least 3.3-fold (0.52 log units) between middle value and limit.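

In this assay, bromo on this aromatic carbon, para to a large group, also gives a large step, both against hydrogen (an at least 36-fold higher number from compound 1 to compound 4 (1.56 log units; beyond the scatter)) and against methyl (an at least 24-fold higher number from compound 2 to compound 4 (1.38 log units; beyond the scatter)). The loss at this position is therefore not confined to chloro, although it does not hold for every group: methyl in compound 2 goes against it and stays within the scatter of compound 1. The readings of compound 3 and compound 4 are both limits and not numbers, so no order of chloro and bromo can be given, and the step between them cannot be read, because both sit at the same ceiling: the limit of > 1000000 nM in this assay, at which 2 of the 4 values shown sit.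

Going by these compounds, how far beyond the limit compound 3 and compound 4 lie remains open. Also open, on these data alone, is whether fluoro, methoxy, an amine or a carboxylic acid at this position would follow bromo and chloro or follow methyl.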